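Removing a ring methyl from a chromone dithiocarbamate

This account rests on a few compounds, and the source may have more. Where it says the series, first, only, none or still open, it means among the compounds named here.

Of the compounds shown here, two have been measured in a functional assay on HeLa cells (Homo sapiens) for antiproliferative activity, read by MTT assay, with a stated time of 72 h; a higher number here means a weaker inhibitor, a lower number a stronger inhibitor. Compound 1 `CN1CCN(C(=S)SCc2coc3ccccc3c2=O)CC1` gives 5900 nM. Compound 2 `Cc1ccc2c(=O)c(CSC(=S)N(C(C)C)C(C)C)coc2c1` gives 1400 nM, the lower of the two numbers, with compound 1 at a higher number by a margin beyond the scatter. Compound 3 `CC(C)N(C(=S)SCc1coc2ccccc2c1=O)C(C)C` is not yet measured; it differs from compound 2 by hydrogen in place of methyl on an aromatic carbon. Within the data shown here, no measured pair isolates this change, so the step is expected to be small, most likely toward a slightly higher number, possibly none beyond the scatter. Compound 3 is estimated at 2500 nM, between 1000 nM and 6500 nM, a step of a 1.8-fold higher number from compound 2 to compound 3 (0.25 log units; within the scatter).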

Compound 3, half-maximal inhibitory concentration: > 30000 nM
Compound 3: a limit, no number; the forecaster's own chance of this, stated with the estimate: 5%; middle value at least 12-fold (1.07 log units) from the limit.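

Compound 3 gives a limit, not a number: the limit of > 30000 nM in this assay, at which 1 of the 3 values shown sits. A single ring methyl therefore carries far more weight than its one carbon suggests: replacing it with hydrogen gives an at least 21-fold higher number from compound 2 to compound 3 (1.33 log units; beyond the scatter). Without that methyl, the diisopropylamino compound also falls behind the 4-methylpiperazin-1-yl compound, with an at least 5.0-fold higher number from compound 1 to compound 3 (0.70 log units; beyond the scatter), so diisopropylamino alone does not secure activity on the unmethylated core. From the compounds shown here alone, how ethyl or methoxy on this aromatic carbon would compare with methyl stays open. So does the effect of adding the methyl to compound 1.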